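Chloro to fluoro at the limit of a cytotoxicity assay

A few compounds are considered here, and "the series" means these few. Any claim that something is new, unique, unknown or untested is made for them only; others in the source may bear on it.

Compound 1 `O=[N+]([O-])c1cn2c(n1)OC[C@@H](OCc1ccc(-c3ccc(OC(F)(F)F)cc3)cc1Cl)C2`: in an ADME assay on Vero cells (Chlorocebus sabaeus) for cytotoxicity, with a stated time of 72 h (a lower number here means a stronger inhibitor, a higher number a weaker inhibitor), compound 1 gives > 128000 nM, which is a limit of the assay and not a number.
Compound 2 `O=[N+]([O-])c1cn2c(n1)OC[C@@H](OCc1ccc(-c3ccc(OC(F)(F)F)cc3)c(Cl)c1)C2`: in this assay compound 2 gives > 128000 nM, again a limit.
Compound 3 `O=[N+]([O-])c1cn2c(n1)OC[C@@H](OCc1ccc(-c3ccc(OC(F)(F)F)cc3)cc1F)C2`: in this assay compound 3 gives > 128000 nM, also a limit.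

Compound 1 and compound 2 are built from the same atoms joined differently; the difference between the two cores is not broken down here. Compound 3 arises from compound 1 by fluoro in place of chloro on an aromatic carbon. The step that the two limits leave unreadable from compound 1 to compound 3 cannot be read because both values sit at the limit of > 128000 nM in this assay, at which 3 of the 3 values shown sit.

Compound 4 `O=[N+]([O-])c1cn2c(n1)OC[C@@H](OCc1ccc(-c3ccc(OC(F)(F)F)cc3)c(F)c1)C2` has not been measured yet. It arises from compound 2 by fluoro in place of chloro on an aromatic carbon, and the surroundings of the place are described in the same words as for the change from compound 1 to compound 3, so it is the same change made on the other core. Compound 4 is expected to give 200000 nM in this assay, with a likely range from 100000 nM to 500000 nM, and most probably only a limit will be reported again. The expected step is a step that the limit leaves unreadable from compound 2 to compound 4, meaning essentially no readable movement. This expectation rests on compound 2 sitting at the limit > 128000 nM and on the unreadable step that the two limits leave unreadable from compound 1 to compound 3, the same kind of change having left compound 3 at the limit as well.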

Compound 4, half-maximal inhibitory concentration: > 128000 nM
Compound 4 gave a limit, no number; the forecaster's own chance of this, stated with the estimate: 85%; the middle value lies beyond the limit too.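

In this assay compound 4 gives > 128000 nM, again a limit of the assay and not a number. No step can be read from compound 2 to compound 4, since neither compound has a number to compare: the limit of > 128000 nM in this assay, at which 4 of the 4 values shown sit.

The compounds shown leave open how toxic any of the four is to these cells, and whether fluoro in place of chloro changes that toxicity at all.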